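From a Methyl to a Methoxy Group on the Aniline

The source may report more compounds than this note shows. Statements on the series, on what has been measured and on what is new or still open speak of the compounds shown alone.

Of the compounds shown here, three built on one shared core have been tested in a functional assay on ECa-109 cells (Homo sapiens) for inhibition, read by MTT assay, with a stated time of 72 h; on this read-out higher numbers stand for weaker inhibition and lower numbers for stronger inhibition. For compound 1 `CC(C)c1ccc(-c2nc(SCc3cn(CC(=O)NC(=O)Nc4ccccn4)nn3)nc(Nc3ccc(F)cc3)c2C#N)cc1` this assay reports only a limit, > 64000 nM. Compound 2 `CC(C)c1ccc(-c2nc(SCc3cn(CC(=O)NC(=O)Nc4ccccn4)nn3)nc(Nc3cccc([N+](=O)[O-])c3)c2C#N)cc1` gives 31300 nM in this assay, and compound 3 `Cc1ccc(Nc2nc(SCc3cn(CC(=O)NC(=O)Nc4ccccn4)nn3)nc(-c3ccc(C(C)C)cc3)c2C#N)cc1` gives 6700 nM, the lowest of the two actual numbers, with compound 2 its nearest neighbour. The steps of a 4.7-fold lower number from compound 2 to compound 3 (0.67 log units; beyond the scatter) and an at least 9.5-fold lower number from compound 1 to compound 3 (0.98 log units; beyond the scatter) show that exchanging the aryl group on the nitrogen of the core moves this assay well beyond the scatter.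

Compound 4 `COc1ccccc1Nc1nc(SCc2cn(CC(=O)NC(=O)Nc3ccccn3)nn2)nc(-c2ccc(C(C)C)cc2)c1C#N` carries the change (2-methoxyphenyl in place of 4-methylphenyl on a nitrogen on an aromatic ring). The measured steps that bear on it are those in which that same aryl group was exchanged, an at least 2.0-fold lower number from compound 1 to compound 2 (0.31 log units; beyond the scatter) and a 4.7-fold lower number from compound 2 to compound 3 (0.67 log units; beyond the scatter), each beyond the scatter. None of them involves a methoxy group, and compound 3 holds the best number among the three, which leaves more room for a weaker read-out than a stronger one. For compound 4 a modest rise in this assay is expected, estimated as a 2.2-fold higher number from compound 3 to compound 4 (0.35 log units; beyond the scatter). Compound 4 is expected to give about 15000 nM in this assay, within a range from 4000 nM to 60000 nM.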

Compound 4, half-maximal inhibitory concentration: 8960 nM
Compound 4: middle estimate off by 1.7-fold (0.22 log units), on the high side; the measured number falls inside the stated range.
By their numbers in this assay, from the lowest: compounds 3 and 4 (each within the scatter of the next); then compound 2. At a limit, above all of these: compound 1.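

In this assay the exchange gives a 1.3-fold higher number from compound 3 to compound 4 (0.13 log units; within the scatter), so this position on the nitrogen accepts the 2-methoxyphenyl group and the 4-methylphenyl group without a difference that can be told apart, which the earlier compounds, each with a different aryl group and each separated by more than the scatter, had not shown. The new compound also keeps clear of the other two aryl groups, with a 3.5-fold lower number from compound 2 to compound 4 (0.54 log units; beyond the scatter) and an at least 7.1-fold lower number from compound 1 to compound 4 (0.85 log units; beyond the scatter), so among the four compounds the 3-nitrophenyl and 4-fluorophenyl groups are the ones that give the higher read-outs. The step from compound 1 rests on a limit and not on a number: the limit of > 64000 nM in this assay, at which 1 of the 4 values shown sits.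

Because the group on the ring and its place both differ between compound 3 and compound 4, the compounds shown cannot separate the two, and it stays open how much either one contributes. Equally open, as far as these compounds go, is how a plain phenyl group, or an ethoxy group or an amine on that ring, would read at this position on the shared core.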